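Swapping a Pyridine for an Iodophenyl on a Hydrazide

The source may hold more compounds than are shown below. What is called first, only, known or untested is meant among the compounds shown, and "the series" means these compounds.

Compound 1 `O=C(N/N=C/C1=C(Cl)c2ccccc2CCC1)c1cccnc1` carries a pyridin-3-yl group on its carbonyl carbon, and in a functional assay on IMR-32 cells (Homo sapiens) for inhibition, read by sulforhodamine B assay, with a stated time of 48 h (on this read-out lower numbers stand for stronger inhibition of growth and higher numbers for weaker inhibition of growth), compound 1 gives 150 nM. Compound 2 `O=C(N/N=C/C1=C(Cl)c2ccccc2CCC1)c1cccc(I)c1` differs from it by 3-iodophenyl in place of pyridin-3-yl on a carbonyl carbon; in this assay compound 2 gives 7600 nM, so that a 51-fold higher number from compound 1 to compound 2 (1.70 log units; beyond the scatter). Compound 3 `Cc1cc2c(cc1C)C(Cl)=C(/C=N/NC(=O)c1cccnc1)CCC2` keeps the pyridin-3-yl group on a different core; the difference between the two cores is not broken down here. In this assay compound 3 gives 8400 nM, close to compound 2. Compound 4 `Cc1cc2c(cc1C)C(Cl)=C(/C=N/NC(=O)c1cccc(I)c1)CCC2` differs from compound 3 by 3-iodophenyl in place of pyridin-3-yl on a carbonyl carbon, the same change that separated compound 1 from compound 2. For compound 4 a step of a 3.6-fold higher number from compound 3 to compound 4 (0.55 log units; beyond the scatter) is expected, smaller than the earlier one. This rests on compound 3 already giving 8400 nM, so a full repeat would carry the number far past anything seen here. The estimate for compound 4 is 30000 nM, between 7000 nM and 200000 nM.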

Compound 4, concentration for 50% growth inhibition: 1900 nM
Estimate against measurement, compound 4: 16-fold (1.20 log units) above, outside the stated range (below it).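

On the core of compound 3, the 3-iodophenyl group goes with stronger growth inhibition in this assay, the opposite of what it did on the core of compound 1, with a 4.4-fold lower number from compound 3 to compound 4 (0.65 log units; beyond the scatter) for this pair. The same swap on a carbonyl carbon therefore does not carry over from one core to the other, in either direction or size: the same change on two cores in this assay, a 51-fold higher number (1.70 log units; beyond the scatter) from compound 1 to compound 2 and a 4.4-fold lower number (0.65 log units; beyond the scatter) from compound 3 to compound 4, 220-fold (2.35 log units) apart, beyond the scatter of two such steps. This shows that the outcome of the swap depends on the core in these two pairs, but it does not show which part of the core matters, why, or what would happen on a third core.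

As far as these compounds go, it remains open how a phenyl ring carrying an amine or a carboxylic acid instead of iodine would behave on each core. The compounds shown also include no step that changes the core alone.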